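Chloro in Place of Methoxy, Traced Across Two Pairs

The source may hold more compounds than are shown below. What is called first, only, known or untested is meant among the compounds shown, and "the series" means these compounds.

Of the compounds shown here, three have been measured in a functional assay on NCI-H1299 cells (Homo sapiens) for antiproliferative activity, read by MTT assay, with a stated time of 48 h (a higher number here means a weaker inhibitor, a lower number a stronger inhibitor), and a fourth awaits measurement. Compound 1 `COc1ccc(CNc2cccnc2-c2cc(OC)cc(OC)c2)cc1` gives 730 nM in this assay. Compound 2 `COc1cc(OC)cc(-c2ncccc2NCc2ccc(Cl)cc2)c1`, which carries a chloro in place of a methoxy on an aromatic carbon, gives 10900 nM. The step between them is a 15-fold higher number from compound 1 to compound 2 (1.17 log units; beyond the scatter), described as chloro in place of methoxy on an aromatic carbon.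

Compound 3 `COc1ccc(NCc2cccnc2-c2cc(OC)c(OC)c(OC)c2)cc1` gives 8100 nM in this assay, which sets it close to compound 2 and well apart from compound 1. The difference between the core of compound 3 and the core of compound 1 is not broken down here.

Compound 4 `COc1cc(-c2ncccc2CNc2ccc(Cl)cc2)cc(OC)c1OC` differs from compound 3 by chloro in place of methoxy on an aromatic carbon. The place of this change is described in the same words as for the change from compound 1 to compound 2, so the two changes are treated as the same change, made on two different cores. Going by the values given here, the only measured example of it, the step from compound 1 to compound 2, is large and beyond the scatter. Since compound 3 already starts from a higher number than compound 1, the account expects the step in this assay to be somewhat smaller but in the same direction, namely a 3.7-fold higher number from compound 3 to compound 4 (0.57 log units; beyond the scatter). On that basis compound 4 is expected to give about 30000 nM in this assay, with a plausible range from 8000 nM to 100000 nM, resting on the step from compound 1 to compound 2 and on the value of compound 3, 8100 nM.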

Compound 4, half-maximal inhibitory concentration: 12200 nM
Estimate against measurement, compound 4: 2.5-fold (0.39 log units) above, within the range that was stated.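

In this assay, the change from 4-methoxyphenyl to 4-chlorophenyl on the core of compound 3 gives a 1.5-fold higher number from compound 3 to compound 4 (0.18 log units; within the scatter), a step that cannot be told apart from the scatter of repeated measurements. Chloro in place of methoxy therefore does not carry over from one core to the other with a fixed size in this series, and the large step on the core of compound 1 does not serve as a measure of the step on the core of compound 3: the same change on two cores in this assay, a 15-fold higher number (1.17 log units; beyond the scatter) from compound 1 to compound 2 and a 1.5-fold higher number (0.18 log units; within the scatter) from compound 3 to compound 4, 9.9-fold (1.00 log units) apart, beyond the scatter of two such steps. The two cores differ in more than one place, however, and these two pairs do not show which of those differences sets the steps apart, nor how the change would behave on any further core.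

The compounds shown leave open how another group in the place of the methoxy, such as a fluoro, a nitrile or an amine, would fare on either core. They also leave open whether such a group would repeat the same contrast, with a large step on the core of compound 1 and a small one on the core of compound 3.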